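Cytotoxicity notes on the shared core, compound 1 to 3

The source may report more compounds than this note shows. Statements on the series, on what has been measured and on what is new or still open speak of the compounds shown alone.

Measured compounds:
compound 1 `O=C(O)CCC(=O)Nc1ccc(-c2nc3cc(C(F)(F)F)ccc3[nH]2)cc1` gives > 100000 nM
compound 2 `O=C(Nc1ccc(-c2nc3cc(C(F)(F)F)ccc3[nH]2)cc1)Nc1ccc(-c2nc3cc(C(F)(F)F)ccc3[nH]2)cc1` gives > 100000 nM

In an ADME assay on MT4 cells (Homo sapiens) for cytotoxicity, read by MTT assay, with a stated time of 96 h (on this read-out lower numbers stand for higher toxicity in this test and higher numbers for lower toxicity in this test), compound 1 gives > 100000 nM, which is a limit of the assay and not a number. Compound 2 gives > 100000 nM, likewise a limit. Compound 1 thus stands at the ceiling of the numbers shown, with both measured values sitting there (the limit of > 100000 nM in this assay, at which 2 of the 2 values shown sit). Within the data shown here, no pair of measured compounds differing in one place is available, so no measured step can anchor the next change.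

Compound 3 `O=C(CN1CCCC1)Nc1ccc(-c2nc3cc(C(F)(F)F)ccc3[nH]2)cc1` has not yet been tested in this assay. Against compound 1 it reads (pyrrolidin-1-yl in place of carboxymethyl on a saturated chain carbon bound to a carbonyl carbon), that is, pyrrolidin-1-yl in place of carboxymethyl on a saturated chain carbon bound to a carbonyl carbon, the same difference reading 2-carboxyethyl to (pyrrolidin-1-yl)methyl when cut one bond further out.

With only limit values in hand, the step from compound 1 to compound 3 is expected to be none beyond the scatter, a number no higher from compound 1 to compound 3 (the limit leaves the size open). Compound 3 is accordingly estimated at 100000 nM in this assay, between 30000 nM and 300000 nM, most likely again reported as a limit.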

Compound 3, half-maximal cytotoxic concentration: 18000 nM
Compound 3: middle estimate off by 5.6-fold (0.74 log units), on the high side, outside the stated range (below it).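

In this assay, compound 3 gives 18000 nM, which shows that this place, a saturated chain carbon bound to a carbonyl carbon, can move the read-out on the shared core, something the two earlier compounds could not show. With pyrrolidin-1-yl in place of carboxymethyl the change reads an at least 5.5-fold lower number from compound 1 to compound 3 (0.74 log units; beyond the scatter), and its full size stays unsettled, since one end of the step is a limit of the assay and not a number. Compound 3 is also the only compound here to give a number rather than a limit, so it provides the first measured value in the series against which a further change at this place can be read: the limit of > 100000 nM in this assay, at which 2 of the 3 values shown sit.

The step cannot be divided among its parts, since the carboxylic acid leaves, the pyrrolidine ring enters and the chain changes from 2-carboxyethyl to (pyrrolidin-1-yl)methyl all at once. Open too, as far as these compounds go, is whether a piperidin-1-yl group, a morpholin-4-yl group, an open-chain dimethylamino group or a longer chain carrying the pyrrolidin-1-yl group would give a number in this assay close to that of compound 3, or would stay at the limit.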